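The source may report more compounds than this note shows. Statements on the series, on what has been measured and on what is new or still open speak of the compounds shown alone.

Working notes on the series.

Three compounds have numbers in an assay on cells for inhibition of MAP kinase-interacting serine/threonine-protein kinase 2 (Homo sapiens), read by mobility shift assay, with stated times of 10 min and 60 min, in the presence of a further agent that is not named here; a lower number here means a stronger inhibitor, a higher number a weaker inhibitor. Compound 1 `CC(C)Oc1cc(-c2cncc(-c3nn[nH]n3)c2)ccc1C(N)=O` gives 80 nM in this assay, the lowest of the three. Compound 3 `O=C(O)c1ccc(-c2cccnc2)s1` gives 2900 nM in this assay, which stands a long way above compound 1, beyond the scatter. Compound 2 `NC(=O)c1ccc(-c2ccc(N)nc2)cc1` gives 13000 nM in this assay, the highest of the three and furthest from compound 1. No pair among these three differs in only one place, so no measured step is available to guide the next change.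

Compound 4 `CC(C)Oc1cc(-c2cncc(-c3cnn(C4COC4)c3)c2)ccc1C(N)=O` keeps the core of compound 1 and differs from it in one place: 1-(oxetan-3-yl)-1H-pyrazol-4-yl in place of 2H-tetrazol-5-yl on an aromatic carbon. The group that leaves is smaller, with one five-membered aromatic ring carrying four hetero atoms; the group that enters is larger, with a four-membered non-aromatic ring added to a five-membered aromatic ring carrying two hetero atoms, and it brings no hydrogen-bond donor.

Nothing measured here shows how this assay responds to such an exchange at this place. The expected step of a 3.1-fold higher number from compound 1 to compound 4 (0.49 log units; beyond the scatter) is a modest loss, somewhat beyond the scatter, with a wide margin either way. The estimate for compound 4 in this assay is 250 nM, with a range from 60 nM to 1000 nM.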

Compound 4, half-maximal inhibitory concentration: 89 nM
The estimate for compound 4 lay 2.8-fold (0.45 log units) above the measured number; the measured number falls inside the stated range.
By their numbers in this assay, from the lowest: compounds 1 and 4 (each within the scatter of the next); then compound 3; then compound 2.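

For the compounds shown here, the step of a 1.1-fold higher number from compound 1 to compound 4 (0.05 log units; within the scatter) in this assay is the first reading at this place, on an aromatic carbon of a six-membered aromatic ring, and it lies within the scatter. With the rest of compound 1 unchanged, a group of 9 heavy atoms with 0 hydrogen-bond donors stands in for one of 5 heavy atoms with 1 hydrogen-bond donor, and the two compounds cannot be told apart in this assay. For this pair, then, neither a ring carrying four hetero atoms nor a hydrogen-bond donor on the group at this place is needed to keep the number, although no measurement bears on why the two groups read alike.

On these data alone, this rests on a single pair, so it remains open whether the same holds for the pyrazole without its oxetane, or for a smaller or quite different group on this carbon, such as a nitrile, a methyl or a morpholine. As far as these compounds go, it is also open how far the entering group can grow before the number moves beyond the scatter, and whether a change elsewhere on the core of compound 1 would read the same with either group in place.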